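A few compounds are considered here, and "the series" means these few. Any claim that something is new, unique, unknown or untested is made for them only; others in the source may bear on it.

Measured so far in a functional assay (strain AB) with Danio rerio as the target, read by microscopy, with a stated time of 1 h; a higher number here means that more compound is needed for the effect, a lower number that less compound is needed
compound 1 `CCN1CCc2c(sc(NC(=O)Nc3ccc(Cl)cc3)c2C(N)=O)C1` gives 3120 nM
compound 2 `NC(=O)c1c(NC(=O)Nc2ccc(Cl)cc2)sc2c1CCN(CC1CCC1)C2` gives 1360 nM
compound 3 `NC(=O)c1c(NC(=O)Nc2ccc(Cl)cc2)sc2c1CCN(CC1CCCC1)C2` gives 1830 nM

Compound 3 stands at 1830 nM in this assay and cannot be told apart from the other two: the steps of a 1.7-fold lower number from compound 1 to compound 3 (0.23 log units; within the scatter) and a 1.3-fold higher number from compound 2 to compound 3 (0.13 log units; within the scatter) both lie within the scatter.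

Next is compound 4 `COCCCN1CCc2c(sc(NC(=O)Nc3ccc(Cl)cc3)c2C(N)=O)C1` with 2-methoxyethyl in place of cyclopentyl on a saturated chain carbon bound to an amine nitrogen in a ring.

All three measured steps change the group at this same place. The largest, a 2.3-fold lower number from compound 1 to compound 2 (0.36 log units; beyond the scatter) is modest, and the other two stay within the scatter. Going by the values given here, no measured compound carries 2-methoxyethyl, so the data give no direction for this change. No step beyond the scatter is therefore expected in this assay from this change. The estimated step is a 1.1-fold higher number from compound 3 to compound 4 (0.04 log units; within the scatter) and it is expected to stay within the scatter. For compound 4 the expected value is 2000 nM with an estimated range from 900 nM to 4500 nM as the working bounds.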

Compound 4, half-maximal effective concentration: 2400 nM
Compound 4: the middle estimate sits 1.2-fold (0.08 log units) below what was measured, and the stated range covers the measured number.
By their numbers in this assay, from the lowest: compounds 2, 3, 4 and 1 (each within the scatter of the next, the first and the last beyond it).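

Going by these compounds alone, compound 4 is the only compound here whose group at this place carries a hydrogen-bond acceptor, and in this assay it shows a 1.3-fold higher number from compound 3 to compound 4 (0.12 log units; within the scatter) together with a 1.8-fold higher number from compound 2 to compound 4 (0.25 log units; within the scatter) and a 1.3-fold lower number from compound 1 to compound 4 (0.11 log units; within the scatter) so it cannot be told apart from any of the three other compounds. Replacing cyclopentyl with 2-methoxyethyl removes the ring and adds that acceptor, yet this change gives no step beyond the scatter. Nothing measured here bears on what lies behind this result.

As far as these compounds go, whether an amine or a carboxylic acid on this chain, or a chain longer than 3-methoxypropyl, would give a step beyond the scatter remains open. Also open, from the compounds shown here alone, is whether the ether oxygen itself matters, since a plain butyl chain would be the direct comparison for 3-methoxypropyl.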